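Swapping a Ring Substituent on a Piperazine-Linked Core

The compounds below may be only part of what the source reports. "The series", "measured", "known", "first", "only" and "open" are said of these compounds alone.

Compound 1, `O=c1oc2cccnc2n1CN1CCN(c2ccccc2)CC1`, gives 5.9 mg/kg in a functional assay on the whole organism with Mus musculus as the target; a higher number here means that more compound is needed for the effect, a lower number that less compound is needed.
Compound 2, `O=c1oc2cccnc2n1CN1CCN(c2cccc(Cl)c2)CC1`, gives 10.5 mg/kg in this assay.

Within the data shown here, compound 2 shows the higher of the two numbers so far, but the gap to compound 1 is small: a 1.8-fold higher number from compound 1 to compound 2 (0.25 log units; within the scatter). The two values are therefore indistinguishable within the usual scatter of this assay.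

Compound 3, `COc1ccccc1N1CCN(Cn2c(=O)oc3cccnc32)CC1`, has not yet been measured. It differs from compound 2 in one place: 2-methoxyphenyl in place of 3-chlorophenyl on an amine nitrogen in a ring. Among the measured compounds shown here, no measured step touches this kind of exchange; the only step known, from compound 1 to compound 2, concerned a chloro in place of hydrogen on an aromatic carbon and stayed within the scatter. On that slim basis compound 3 is expected to land near its neighbours, with a step of a 1.5-fold lower number from compound 2 to compound 3 (0.18 log units; within the scatter), not beyond the scatter. The estimate for compound 3 in this assay is 7 mg/kg, with a plausible range from 3 mg/kg to 17 mg/kg.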

Compound 3, dose for half-maximal effect: > 25 mg/kg
Compound 3: a limit, no number (the forecaster's own chance of this, stated with the estimate: 5%); at least 3.5-fold (0.55 log units) between middle value and limit.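

Unlike the chloro exchange, which gave a 1.8-fold higher number from compound 1 to compound 2 (0.25 log units; within the scatter), a change at this same aromatic group now moves the result clearly: 2-methoxyphenyl in place of 3-chlorophenyl gives an at least 2.3-fold higher number from compound 2 to compound 3 (0.37 log units; beyond the scatter), and methoxy in place of hydrogen gives an at least 4.2-fold higher number from compound 1 to compound 3 (0.62 log units; beyond the scatter). So the aromatic group on the amine nitrogen in the ring is not indifferent to what it carries, since both steps to the methoxy compound lie beyond the scatter while the chloro step does not. The result for compound 3 in this assay is a limit and not a number: the limit of > 25 mg/kg in this assay, at which 1 of the 3 values shown sits.

As far as these compounds go, how far compound 3 truly lies from the other two therefore stays unknown. Also open, from the compounds shown here alone, is whether another group in the same place, such as an ethoxy, a hydroxy or an amine, would give a similar result.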